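Chlorobenzyl purines: cytotoxicity notes, compound 3 to compound 4

The source may report more compounds than this note shows. Statements on the series, on what has been measured and on what is new or still open speak of the compounds shown alone.

Measured so far:
compound 1, `Nc1nc(Cl)c2ncn(Cc3ccc(CCl)cc3)c2n1`, 75900 nM
compound 2, `ClCc1ccccc1Cn1cnc2ncnc(Cl)c21`, 24000 nM
compound 3, `ClCc1ccc(Cn2cnc3ncnc(Cl)c32)cc1`, 4160 nM

The three measured compounds share a core that carries a chloro group and a chloromethyl-substituted benzyl group. In a functional assay on A549 cells (Homo sapiens) for cytotoxicity, read by sulforhodamine B assay, with a stated time of 48 h (on this read-out higher numbers stand for weaker inhibition of growth and lower numbers for stronger inhibition of growth), compound 1 gives 75900 nM, the highest number of the three. Compound 2 gives 24000 nM. Compound 3 gives 4160 nM, the lowest number of the set; its gaps to compound 2 and to compound 1 both lie beyond the scatter, so compound 3 is the strongest inhibitor of growth among the measured compounds.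

Compound 4, `ClCc1ccc(Cn2cnc3nc(Cl)nc(Cl)c32)cc1`, is not yet measured. It differs from compound 3 in one place: chloro in place of hydrogen on an aromatic carbon. The new chloro sits between two ring nitrogen atoms, meta to the chloro group already present.

Among the measured compounds shown here, no measured pair isolates this change, so the size of the step can only be guessed. A small step is expected, most likely within the scatter, with a slight lean toward stronger inhibition of growth; the expected step is a 1.4-fold lower number from compound 3 to compound 4 (0.14 log units; within the scatter). In this assay compound 4 is estimated at 3000 nM, with a range from 800 nM to 12000 nM.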

Compound 4, concentration for total growth inhibition: 4070 nM
Estimate against measurement, compound 4: 1.4-fold (0.13 log units) below, and the stated range covers the measured number.
By their numbers in this assay, from the lowest: compounds 4 and 3 (each within the scatter of the next); then compound 2; then compound 1.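

In this assay, chloro in place of hydrogen on an aromatic carbon, between two ring nitrogen atoms and meta to a chloro group, gives a 1.0-fold lower number from compound 3 to compound 4 (0.01 log units; within the scatter). Among the compounds shown here, this is the first step that can be read at a single place, since the earlier compounds offered no such step, and it shows that this position can carry a second chloro group with no difference from the hydrogen of compound 3 that can be told from the scatter. Nothing shown bears on why this step is so small.

One chloro group at this position says little about other groups there: a methoxy group, a carboxylic acid or a longer alkyl chain could each give a number within the scatter of compound 3 or well away from it. From the compounds shown here alone, whether the same chloro for hydrogen step would read alike on the benzyl arrangement of compound 2, or in cells other than those of this assay, also stays open.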